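The source may hold more compounds than are shown below. What is called first, only, known or untested is meant among the compounds shown, and "the series" means these compounds.

Measured compounds:
compound 1, `O=c1ccoc2cc(OCc3cn(Cc4cccc([N+](=O)[O-])c4)nn3)ccc12` — 9450 nM
compound 2, `CC(C)(C)c1ccc(Cn2cc(COc3ccc4c(=O)ccoc4c3)nn2)cc1` — > 100000 nM

In a functional assay on A549 cells (Homo sapiens) for cytotoxicity, read by MTT assay, with a stated time of 48 h (a lower number here means a stronger inhibitor, a higher number a weaker inhibitor), compound 1 gives 9450 nM. For compound 2 the assay returned no number, only a limit, > 100000 nM. Compound 2 thus stands at the limit of > 100000 nM in this assay, at which 1 of the 2 values shown sits, the weak end of what has been measured in the series, and how far beyond that point it lies is not known. The two values shown differ by well more than the usual scatter, so compound 1 is the stronger of the two.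

Compound 3, `COc1ccc(Cn2cc(COc3ccc4c(=O)ccoc4c3)nn2)cc1`, remains to be measured. It differs from compound 2 by methoxy in place of tert-butyl on an aromatic carbon, para to a large group. Going by the values given here, no pair of measured compounds covers this change, so its size in this assay is open. The expected step is an at least 1.2-fold lower number from compound 2 to compound 3 (0.09 log units; that floor lies within the scatter), toward a somewhat lower number, though it is likely to stay within the region where the assay reports only a limit. Compound 3 is expected to give about 80000 nM, with a range from 20000 nM to 250000 nM.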

Compound 3, half-maximal inhibitory concentration: 16500 nM
Estimate against measurement, compound 3: 4.8-fold (0.69 log units) above, and the stated range ends above it.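

In this assay, methoxy in place of tert-butyl on an aromatic carbon, para to a large group, gives an at least 6.0-fold lower number from compound 2 to compound 3 (0.78 log units; beyond the scatter), the first sign in this series that the group at this position can move the read-out beyond the scatter, and the step marks only the smallest size it can have. As far as these compounds go, the value of compound 2 is a limit and not a number, so the true size of the step stays unknown: the limit of > 100000 nM in this assay, at which 1 of the 3 values shown sits. Changing both the group and its place on the ring, 4-methoxyphenyl in place of 3-nitrophenyl on a saturated chain carbon bound to an aromatic nitrogen, gives a 1.7-fold higher number from compound 1 to compound 3 (0.24 log units; within the scatter), so this assay does not separate these two compounds.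

The compounds shown leave open whether the position tolerates most groups with tert-butyl as the exception, or whether methoxy and nitro are particular cases; the unsubstituted phenyl ring, a fluorine, an amine or a carboxylic acid at the same place would help to settle this. Going by these compounds alone, also open is how methoxy and nitro compare when each is held at the same place on the ring, since the one step linking them changes the group and its place together.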